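This account rests on a few compounds, and the source may have more. Where it says the series, first, only, none or still open, it means among the compounds named here.

Measured compounds in a functional assay on CCRF-CEM cells (Homo sapiens) for antiproliferative activity, read by resazurin assay, with a stated time of 72 h; a lower number here means a stronger inhibitor, a higher number a weaker inhibitor:
- compound 1 `COc1ccc(-c2c(C#N)c(-c3ccccc3)nc3c2c(-c2ccccc2)nn3-c2ccccc2)cc1OC`
- compound 2 `N#Cc1c(-c2cccs2)nc2c(c(-c3ccccc3)nn2-c2ccccc2)c1-c1ccc(O)cc1`
- compound 3 `COc1cc(-c2c(C#N)c(-c3ccccc3)nc3c2c(-c2ccccc2)nn3-c2ccccc2)ccc1O`

In this assay compound 1 reaches only the limit > 25000 nM. Compound 2 likewise gives only the limit > 25000 nM. Compound 3 stands at the limit > 50000 nM, so its position among the three is not a number but a bound. Among the measured compounds shown here, the step that the two limits leave unreadable from compound 1 to compound 3 is therefore not readable either; the limit of > 25000 nM in this assay, at which 2 of the 3 values shown sit, and the limit of > 50000 nM in this assay, at which 1 of the 3 values shown sits, are the only evidence, and both are limits.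

Compound 4 `N#Cc1c(-c2ccccc2)nc2c(c(-c3ccccc3)nn2-c2ccccc2)c1-c1ccc(O)cc1` differs from compound 3 by hydrogen in place of methoxy on an aromatic carbon. For the measured compounds named here, no measured step bears on this change with a readable size. Compound 4 is expected to stay at a limit, so an at least 1.2-fold lower number from compound 3 to compound 4 (0.09 log units; that floor lies within the scatter) is estimated as no readable step. The estimate for compound 4 is 40000 nM, within 15000 nM to 100000 nM.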

Compound 4, half-maximal inhibitory concentration: 33400 nM
The estimate for compound 4 lay 1.2-fold (0.08 log units) above the measured number; low and high end bracket the measured number.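

In this assay, among the compounds shown here, compound 4 is the first compound of the series to give a number and not a limit. The change from 4-hydroxy-3-methoxyphenyl to 4-hydroxyphenyl gives an at least 1.4-fold lower number from compound 3 to compound 4 (0.17 log units; that floor lies within the scatter), which is a floor and not a size, and it rests on a limit: the limit of > 50000 nM in this assay, at which 1 of the 4 values shown sits. The steps to compound 4 from compound 1 and from compound 2 cannot be read.

On these data alone, it remains open whether a group other than hydrogen at this place, such as an amine or a carboxylic acid, would move the number. Also open, as far as these compounds go, is what replacing the hydroxy group of compound 4 with a longer chain would do.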